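Swapping cyclohexyl for cyclopropyl on compound 3

A few compounds are considered here, and "the series" means these few. Any claim that something is new, unique, unknown or untested is made for them only; others in the source may bear on it.

Measured so far in an ADME assay on BaF3 cells (Mus musculus) for inhibition, read by CellTiter-Glo, with a stated time of 72 h (on this read-out higher numbers stand for weaker inhibition of growth and lower numbers for stronger inhibition of growth), for three compounds
compound 1 (`Cc1cc(Nc2ncc3c(n2)N(C)C(=O)N(c2cc(NC(=O)c4ccc(CN5CCC(N(C)C)C5)c(C(F)(F)F)c4)ccc2C)C3)n(C)n1`) gives 509 nM
compound 2 (`Cc1ccc(Nc2ncc3c(n2)N(C)C(=O)N(c2cc(NC(=O)c4ccc(C)c(C(F)(F)F)c4)ccc2C)C3)cn1`) gives 870 nM
compound 3 (`Cc1ccc(NC(=O)c2cccc(C(F)(F)F)c2)cc1N1Cc2cnc(NC3CCCCC3)nc2N(C)C1=O`) gives 5220 nM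

Of these three, compound 3 has the highest number and so the weakest inhibition of growth, and its gaps to compound 1 and compound 2 both lie beyond the usual scatter. Compound 4 (`Cc1ccc(NC(=O)c2cccc(C(F)(F)F)c2)cc1N1Cc2cnc(NC3CC3)nc2N(C)C1=O`) differs from compound 3 in one place (cyclopropyl in place of cyclohexyl on a nitrogen on an aromatic ring) with cyclopropyl in place of cyclohexyl on a nitrogen on an aromatic ring. Among the measured compounds shown here, no two measured compounds differ in only one place, so the data give no direct guide to this swap. The expectation therefore starts from compound 3 with 5220 nM as its anchor and assumes no change beyond the scatter. The expected step is a 1.3-fold lower number from compound 3 to compound 4 (0.12 log units; within the scatter) and this estimate stays within the scatter. Compound 4 is estimated at 4000 nM in this assay with an expected range from 1300 nM to 12000 nM around that figure.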

Compound 4, concentration for 50% growth inhibition: 5060 nM
Beside the measured number, compound 4's estimate is 1.3-fold (0.10 log units) below it; measured number inside the range.
By their numbers in this assay, from the lowest: compounds 1 and 2 (each within the scatter of the next); then compounds 4 and 3 (each within the scatter of the next).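

Going from cyclohexyl to cyclopropyl on a nitrogen on an aromatic ring gives a 1.0-fold lower number from compound 3 to compound 4 (0.01 log units; within the scatter) in this assay. Among the compounds shown here, this is the first direct reading of a single change at this position: a carbon-only ring of 6 heavy atoms and one of 3 heavy atoms, neither with hydrogen-bond donors or acceptors, are not told apart by this read-out. No measurement at hand explains this result.

On these data alone, both rings tested in this swap contain carbon only, so whether a piperidine ring or a carboxylic acid on a chain at this nitrogen would also leave the number unmoved stays open. Compound 1 and compound 2 carry other groups here but differ from compound 3 in more than one place, so they cannot settle that question.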